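The source may hold more compounds than are shown below. What is called first, only, known or untested is meant among the compounds shown, and "the series" means these compounds.

In an assay on CHO cells for binding affinity to metabotropic glutamate receptor 2 (Rattus norvegicus) (a lower number here means a stronger inhibitor, a higher number a weaker inhibitor), compound 2 `N[C@]1(C(=O)O)[C@H]2[C@@H](C[C@H]1OCc1c(F)cccc1F)[C@]2(F)C(=O)O` gives 7.02 nM, the lowest of the two numbers in hand; compound 1 `Nc1cccc(CO[C@@H]2C[C@@H]3[C@H]([C@]2(N)C(=O)O)[C@@]3(F)C(=O)O)c1` gives 15.4 nM, and the measured step is a 2.2-fold lower number from compound 1 to compound 2 (0.34 log units; beyond the scatter), a swap of one aromatic substituent pattern for another. Compound 3 `N[C@]1(C(=O)O)[C@H]2[C@@H](C[C@H]1OCc1cc(Cl)cc(Cl)c1)[C@]2(F)C(=O)O` differs from compound 2 by 3,5-dichlorophenyl in place of 2,6-difluorophenyl on a saturated chain carbon bound to an oxygen on a saturated carbon. For the measured compounds named here, only that one measured step bears on an aryl change of this kind, and it was modest, so a step of similar size, in either direction or none beyond the scatter, is expected in this assay. Compound 3 is expected at 10 nM, with a range from 4 nM to 25 nM. The expected step is a 1.4-fold higher number from compound 2 to compound 3 (0.15 log units; within the scatter).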

Compound 3, inhibition constant: 5.61 nM
The estimate for compound 3 lay 1.8-fold (0.25 log units) above the measured number, within the range that was stated.
By their numbers in this assay, from the lowest: compounds 3 and 2 (each within the scatter of the next); then compound 1.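

In this assay, 3,5-dichlorophenyl and 2,6-difluorophenyl on a saturated chain carbon bound to an oxygen on a saturated carbon cannot be told apart (a 1.3-fold lower number from compound 2 to compound 3 (0.10 log units; within the scatter)), so both the halogen and its ring pattern can change here without a step beyond the scatter. Against 3-aminophenyl, the dichloro group gives a modest step (a 2.7-fold lower number from compound 1 to compound 3 (0.44 log units; beyond the scatter)), in the same direction as the difluoro group. No measurement offered explains these results. Still open, from the compounds shown here alone, is whether an unsubstituted phenyl or a ring bearing a carboxylic acid would stay at this level, and whether a longer chain to the aryl ring would be tolerated.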